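The compounds below may be only part of what the source reports. "The series", "measured", "known", "first", "only" and "open" are said of these compounds alone.

Compound 1 `Cc1ccc(S(=O)(=O)c2cnc3ccc(Cl)cc3c2N2CCC(C)CC2)cc1C` is one of two measured compounds; in an assay on isolated protein for displacement of a labelled ligand from metabotropic glutamate receptor 5 (Homo sapiens), with a stated time of 60 min, tested at 1 uM (on this read-out higher numbers stand for more inhibition at the one concentration tested (going by the name of the read-out) and lower numbers for less inhibition), compound 1 gives 84%.
Compound 2 `COc1cccc(S(=O)(=O)c2cnc3ccc(Cl)cc3c2N2CCC(C)CC2)c1` is the other; in this assay compound 2 gives 87%.

Compound 2 stands nearest compound 1, and since the step of a number 3 percentage points higher from compound 1 to compound 2 (within the scatter) lies within the scatter, the two cannot be told apart. Compound 3 `COc1ccc(S(=O)(=O)c2cnc3ccc(Cl)cc3c2N2CCC(C)CC2)cc1OC` differs from compound 2 in one place: methoxy in place of hydrogen on an aromatic carbon. Among the measured compounds shown here, only the step of a number 3 percentage points higher from compound 1 to compound 2 (within the scatter) bears on this change, as it altered the same aryl group on the sulfonyl sulfur, and it stayed within the scatter. The account therefore expects no step beyond the scatter, a number 2 percentage points lower from compound 2 to compound 3 (within the scatter). Compound 3 is estimated at 85%, within 70% to 95%.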

Compound 3, a percentage reported as inhibition, at one concentration (the size of the read-out at that concentration, not a potency): 61%
Beside the measured number, compound 3's estimate is 24 percentage points above it, and the stated range ends above it.
By their numbers in this assay, from the lowest: compound 3; then compounds 1 and 2 (each within the scatter of the next).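

Among the compounds shown here, the added methoxy, ortho to a methoxy group and para to a large group, gives a number 26 percentage points lower from compound 2 to compound 3 (beyond the scatter), the first change to this aryl group that goes beyond the scatter. Two groups on the ring do not by themselves bring such a loss, since replacing 3,4-dimethylphenyl with 3,4-dimethoxyphenyl gives a number 23 percentage points lower from compound 1 to compound 3 (beyond the scatter). Nothing available explains this loss. Still open, on these data alone, is whether a hydroxy, a fluorine or an amine on this carbon would give the same loss, and whether a methoxy there would do so without the neighbouring methoxy group.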